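This account rests on a few compounds, and the source may have more. Where it says the series, first, only, none or still open, it means among the compounds named here.

The measured compounds:
Compound 1, `O=S(=O)(Nc1cccc2c1CCCC2c1c[nH]cn1)C1CC1`: in a functional assay on Urethra with Alpha-1A adrenergic receptor (Oryctolagus cuniculus) as the target (a lower number here means a smaller maximal response, a higher number a larger maximal response), compound 1 gives 51%.
Compound 2, `CC(=O)Nc1cccc2c1CCCC2c1c[nH]cn1`: in this assay compound 2 gives 70%.
Compound 3, `CC(C)S(=O)(=O)Nc1cccc2c1CCCC2c1c[nH]cn1`: in this assay compound 3 gives 74%.

Compound 3 stands highest of the three numbers. The step of a number 23 percentage points higher from compound 1 to compound 3 (beyond the scatter) is beyond the scatter, but the step of a number 4 percentage points higher from compound 2 to compound 3 (within the scatter) is within it, so compound 3 and compound 2 cannot be told apart, and compound 3 is not simply the strongest of the set.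

The unmeasured compound is compound 4, `Nc1cccc2c1CCCC2c1c[nH]cn1`. The change is hydrogen in place of isopropylsulfonyl on a nitrogen on an aromatic ring.

Going by the values given here, no measured step removes the group on that nitrogen altogether; the three steps only exchange one group for another there. The step of a number 19 percentage points higher from compound 1 to compound 2 (beyond the scatter) and the step of a number 23 percentage points higher from compound 1 to compound 3 (beyond the scatter) were modest and beyond the scatter, the step of a number 4 percentage points higher from compound 2 to compound 3 (within the scatter) within it. These steps bear only loosely on compound 4: they show that the maximal response in this assay has shifted modestly with different groups on this nitrogen, but they give no direct guide for a bare amino.

Compound 4 is therefore expected to give about 65%, with a wide range from 42% to 88%. This estimate means a step of a number 9 percentage points lower from compound 3 to compound 4 (within the scatter), which is expected to lie within the scatter.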

Compound 4, largest response reached (reported as efficacy), in percent of the reference or control that the assay uses: 84%
Compound 4: the middle estimate sits 19 percentage points below what was measured; the range from low to high includes it.
By their numbers in this assay, from the lowest: compound 1; then compounds 2, 3 and 4 (each within the scatter of the next, the first and the last beyond it).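

Going by these compounds alone, compound 4 is the first compound here with nothing but hydrogen on this nitrogen, and in this assay the bare amino keeps a high maximal response. Replacing the isopropylsulfonyl group with hydrogen gives a number 10 percentage points higher from compound 3 to compound 4 (within the scatter) and so leaves the two compounds indistinguishable, which shows that this sulfonyl group is not needed to reach this level of response. Replacing the acetyl group gives a number 14 percentage points higher from compound 2 to compound 4 (beyond the scatter) and replacing the cyclopropylsulfonyl group gives a number 33 percentage points higher from compound 1 to compound 4 (beyond the scatter) as the largest of the three new steps, so among these compounds both of those groups sit with a lower response than the bare amino does. Nothing given here explains these differences.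

Still open, going by these compounds, is how small groups on this nitrogen would behave, such as a methyl or a methylsulfonyl group, and whether the nitrogen itself matters, which a hydroxyl group or a plain hydrogen on the aromatic ring in place of the amino would test. On these data alone, the read-out is also only the largest response reached, so the concentration at which each compound acts remains unknown.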